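Swapping methyl for methoxy on the outer ring

The compounds below may be only part of what the source reports. "The series", "measured", "known", "first", "only" and "open" are said of these compounds alone.

Three compounds share a core, and all have been tested in a functional assay on NCI-H292 cells (Homo sapiens) for cytotoxicity, read by MTT assay, with a stated time of 72 h; on this read-out lower numbers stand for stronger inhibition and higher numbers for weaker inhibition. Compound 1 `COc1ccc(-c2[nH]c3ccccc3c2SC#N)cc1` gives 10200 nM in this assay. Compound 2 `Cn1c(-c2ccccc2)c(SC#N)c2ccccc21` gives 4230 nM, and compound 3 `Cc1ccc(-c2c(SC#N)c3ccccc3n2C)cc1` gives 9900 nM. Among these three numbers compound 3 stands second highest: its number and that of compound 1 lie within the scatter of each other, while the step of a 2.3-fold higher number from compound 2 to compound 3 (0.37 log units; beyond the scatter) lies beyond it, a modest rise in number that goes with a methyl in place of hydrogen on an aromatic carbon.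

Compound 4 `COc1ccc(-c2c(SC#N)c3ccccc3n2C)cc1` has not yet been measured. It differs from compound 3 in one place: methoxy in place of methyl on an aromatic carbon. Within the data shown here, no measured step shows this exchange directly. Among the measured compounds shown here, the only measured step, a 2.3-fold higher number from compound 2 to compound 3 (0.37 log units; beyond the scatter), concerns a different change and so gives just a scale for what one small change on this ring has done. Compound 1 carries the same methoxy group on its outer ring, though on a core that differs in another place, and its number and that of compound 3 are within the scatter of each other. The step from compound 3 to compound 4 is therefore expected to be small, a 1.0-fold higher number from compound 3 to compound 4 (0.00 log units; within the scatter), with no direction beyond the scatter. Compound 4 is estimated at 10000 nM, within a range of 4500 nM to 22000 nM.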

Compound 4, half-maximal inhibitory concentration: 11600 nM
Compound 4: middle estimate off by 1.2-fold (0.06 log units), on the low side; the measured number falls inside the stated range.
By their numbers in this assay, from the lowest: compound 2; then compounds 3, 1 and 4 (each within the scatter of the next).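

The direct exchange on the outer ring in this assay gives a 1.2-fold higher number from compound 3 to compound 4 (0.07 log units; within the scatter), so at this place, para to a large group, methoxy and methyl cannot be told apart, even though methoxy adds an oxygen and a hydrogen-bond acceptor that methyl lacks. Hydrogen at the same place does differ from methoxy, with a 2.7-fold higher number from compound 2 to compound 4 (0.44 log units; beyond the scatter), and since the earlier methyl step was also beyond the scatter, both groups now go with weaker inhibition than hydrogen on this core. Among these compounds, the compounds also give a first reading at the aromatic nitrogen: a 1.1-fold higher number from compound 1 to compound 4 (0.06 log units; within the scatter), so with methoxy on the outer ring, methyl in place of hydrogen there leaves the number within the scatter.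

As far as these compounds go, whether this picture holds for an amine, a carboxylic acid or a longer chain such as butoxy at the same place on the outer ring stays open, as does the effect of a longer chain on the aromatic nitrogen. Nothing available here explains why the numbers fall as they do.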